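Flexible aminoalkyl chain replacing a rigid aryl arm

A few compounds are considered here, and "the series" means these few. Any claim that something is new, unique, unknown or untested is made for them only; others in the source may bear on it.

Compound 1 `c1ccc(CNCCCCN(C[C@H]2Cc3ccccc3CN2)[C@H]2CCCc3cccnc32)cc1`: 20.1 nM
Compound 2 `NCc1ccccc1CN(C[C@H]1Cc2ccccc2CN1)[C@H]1CCCc2cccnc21`: 50.8 nM
Compound 3 `NCc1cccc(CN(C[C@H]2Cc3ccccc3CN2)[C@H]2CCCc3cccnc32)c1`: 292 nM

In a functional assay on cells for antagonist activity at C-X-C chemokine receptor type 4 (Homo sapiens), read by fluorescence and calcium flux, with stated times of 25 min and 90 s (a lower number here means a stronger inhibitor, a higher number a weaker inhibitor), compound 3 gives the highest number of the three measured compounds, standing a 5.7-fold higher number from compound 2 to compound 3 (0.76 log units; beyond the scatter) and a 15-fold higher number from compound 1 to compound 3 (1.16 log units; beyond the scatter). Compound 4 `CC(C)(N)CCCN(C[C@H]1Cc2ccccc2CN1)[C@H]1CCCc2cccnc21` differs from compound 3 by 3-amino-3-methylbutyl in place of 3-(aminomethyl)phenyl on a saturated chain carbon bound to an amine nitrogen. For the measured compounds named here, the steps that bear on this change are those that swapped the substituent on the same chain carbon: the move from the flexible chain of compound 1 to an aryl arm cost a 15-fold higher number from compound 1 to compound 3 (1.16 log units; beyond the scatter), and the move between the two aryl arms cost a 5.7-fold higher number from compound 2 to compound 3 (0.76 log units; beyond the scatter). Compound 4 returns to a chain of the kind seen in compound 1, though without its benzyl group, so a lower number than compound 3 is expected in this assay, probably not reaching compound 1. The estimate for compound 4 is therefore 80 nM, with a range from 20 nM to 320 nM, corresponding to an expected step of a 3.7-fold lower number from compound 3 to compound 4 (0.56 log units; beyond the scatter).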

Compound 4, half-maximal inhibitory concentration: 24.6 nM
Estimate against measurement, compound 4: 3.3-fold (0.51 log units) above; the range from low to high includes it.
By their numbers in this assay, from the lowest: compounds 1 and 4 (each within the scatter of the next); then compound 2; then compound 3.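

In this assay, an open chain at this position does not merely improve on the aryl arm: 3-amino-3-methylbutyl in place of 3-(aminomethyl)phenyl recovers the loss seen with that arm (a 12-fold lower number from compound 3 to compound 4 (1.07 log units; beyond the scatter)), and it also gives a lower number than the 2-(aminomethyl)phenyl arm (a 2.1-fold lower number from compound 2 to compound 4 (0.31 log units; beyond the scatter)). The benzyl group of compound 1 is not required for a number of this size, as replacing (benzylamino)methyl with 1-amino-1-methylethyl on the chain leaves the two compounds within the usual scatter (a 1.2-fold higher number from compound 1 to compound 4 (0.09 log units; within the scatter)). Nothing given here explains these differences.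

From the compounds shown here alone, what the two methyl groups of the 3-amino-3-methylbutyl chain contribute stays open. So does whether a plain 4-aminobutyl chain, a longer chain or a hydroxyl group in place of the amine would keep a number of this size.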